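Hydroxymethyl to Methoxy on Two Related Cores

The source may hold more compounds than are shown below. What is called first, only, known or untested is meant among the compounds shown, and "the series" means these compounds.

Compound 1 `CCCn1c(=O)n(CCCO)c(=O)c2[nH]cnc21` and compound 2 `CCCn1c(=O)n(CCOC)c(=O)c2[nH]cnc21` share one core and differ in a single place: methoxy in place of hydroxymethyl on a saturated chain carbon, two bonds along the chain from an aromatic nitrogen. In an assay on Cerebral cortex for binding affinity to adenosine receptor A1 (Cavia porcellus), read by radioligand binding (on this read-out lower numbers stand for stronger inhibition and higher numbers for weaker inhibition), compound 1 gives 12000 nM, while compound 2 gives 2500 nM, so the change made a 4.8-fold lower number from compound 1 to compound 2 (0.68 log units; beyond the scatter). Compound 3 `CCCn1c(=O)n(C)c(=O)c2c1ncn2CCCO` carries the same hydroxymethyl-bearing chain on a second core; the difference between the two cores is not broken down here. In this assay compound 3 gives 112000 nM, the highest of the three numbers. Compound 4 `CCCn1c(=O)n(C)c(=O)c2c1ncn2CCOC` arises from compound 3 through (methoxy in place of hydroxymethyl on a saturated chain carbon, two bonds along the chain from an aromatic nitrogen), the same change as between the first two compounds, at a place described in the same words.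

Compound 4 is therefore expected to show a step of a 4.9-fold lower number from compound 3 to compound 4 (0.69 log units; beyond the scatter), a size that rests on a 4.8-fold lower number from compound 1 to compound 2 (0.68 log units; beyond the scatter). On that basis compound 4 is estimated at 23000 nM, expected to fall between 8000 nM and 70000 nM. The second core has not yet been tested with this change, so the expectation is held loosely until the measurement is in.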

Compound 4, inhibition constant: 12400 nM
For compound 4 the middle estimate is 1.9-fold (0.27 log units) above the measured one; the range from low to high includes it.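

On the core of compound 3, methoxy in place of hydroxymethyl again lowers the number in this assay, with a 9.0-fold lower number from compound 3 to compound 4 (0.96 log units; beyond the scatter). Set beside the earlier step, this one cannot be told apart from it in size: the same change on two cores in this assay, a 4.8-fold lower number (0.68 log units; beyond the scatter) from compound 1 to compound 2 and a 9.0-fold lower number (0.96 log units; beyond the scatter) from compound 3 to compound 4, 1.9-fold (0.27 log units) apart, within the scatter of two such steps. The change therefore carried from one core to the other in this series, in the same direction and with a size that holds within the scatter, but two cores are a small sample: this does not show that it would carry to a further core, and it does not explain why the number falls.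

The compounds shown leave open what an amine, a carboxylic acid or a longer chain would do in place of hydroxymethyl, and whether such a group would behave alike on both cores. Going by these compounds, all of this also rests on a single read-out, so how the same change behaves in any other assay remains open.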